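This account rests on a few compounds, and the source may have more. Where it says the series, first, only, none or still open, it means among the compounds named here.

Measured in a functional assay on MOLT-4 cells (Homo sapiens) for inhibition, read by MTT assay, with a stated time of 4 days (on this read-out higher numbers stand for weaker inhibition and lower numbers for stronger inhibition), so far:
- compound 1 (`COc1cc(NC(C)CCCNC(=O)NNC(=O)NCCCCCO)c2ncccc2c1`) reads >= 250000 nM as a limit
- compound 2 (`COc1ccc(/C(=N/NC(=O)NCCCC(C)Nc2cc(OC)cc3cccnc23)c2ccccc2)cc1`) reads >= 250000 nM as a limit
- compound 3 (`COc1cc(NC(C)CCCNC(=O)NNC(=O)NCCCC(C)Nc2cc(OC)cc3cccnc23)c2ncccc2c1`) reads >= 250000 nM as a limit

Compound 1 has no number, only a limit, and it stands level with the other two. Among the compounds with values here, the picture so far is the limit of >= 250000 nM in this assay, at which 3 of the 3 values shown sit, and no measured step exists.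

Next is compound 4 (`COc1cc(NC(C)CCCNC(=O)Nc2ccc(Cl)c(C(F)(F)F)c2)c2ncccc2c1`), which keeps the shared core. The change from compound 1 is 4-chloro-3-(trifluoromethyl)phenyl in place of ((5-hydroxypentyl)carbamoyl)amino on an amide-type nitrogen and it puts one six-membered aromatic ring of carbon only where an open chain ended in hydroxypentyl.

Within the data shown here, compound 1 gives >= 250000 nM as a limit, so the expectation can only point towards lower numbers, and the data offer no measured step to size it. In this assay a drop towards stronger inhibition beyond the usual scatter is expected, with an at least 10-fold lower number from compound 1 to compound 4 (1.00 log units; beyond the scatter) as the estimated step. This expectation is loose, and another limit reading remains possible. Compound 4 is expected at 25000 nM as the estimate, with 4000 nM to 200000 nM as its estimated range.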

Compound 4, half-maximal inhibitory concentration: 3400 nM
For compound 4 the middle estimate is 7.4-fold (0.87 log units) above the measured one; the whole stated range lies above it.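

This position, the amide-type nitrogen whose other neighbours are: carbonyl carbon, now responds in this assay: 4-chloro-3-(trifluoromethyl)phenyl in place of ((5-hydroxypentyl)carbamoyl)amino gives an at least 73-fold lower number from compound 1 to compound 4 (1.86 log units; beyond the scatter). Compound 1 carries a limit and no number, so this step holds only as a bound and its full size cannot be read. Compound 4 alone gives a measured number, which ties the first reading off the limit to a six-membered aromatic ring of carbon only at this nitrogen, while the other compounds stay at the limit: the limit of >= 250000 nM in this assay, at which 3 of the 4 values shown sit.

Which part of the 4-chloro-3-(trifluoromethyl)phenyl group carries the step stays open, since the compounds shown do not separate the chlorine, the trifluoromethyl and the ring itself, and a plain phenyl or a phenyl with only one of these two groups at the same nitrogen would do so. Also open, as far as these compounds go, is how an amine or a carboxylic acid on that ring would read in this assay.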